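The source may report more compounds than this note shows. Statements on the series, on what has been measured and on what is new or still open speak of the compounds shown alone.

Compound 3 `O=C(N[C@H]1CNC1=O)OCc1ccc(OC2CCCCC2)cc1` gives 2070 nM in an assay on HEK293 cells for inhibition of N-acylethanolamine-hydrolyzing acid amidase (Homo sapiens), read by fluorescence, with stated times of 10 min and 50 min; on this read-out lower numbers stand for stronger inhibition and higher numbers for weaker inhibition. On the numbers at hand it stands highest, and so weakest, among three: the nearest is compound 2 `O=C(N[C@H]1CNC1=O)OCc1ccc(C2CCOCC2)cc1`, which gives 1370 nM, and the furthest is compound 1 `CCCc1ccc(COC(=O)N[C@H]2CNC2=O)cc1`, which gives 52 nM. The step from compound 2 to compound 3 is a 1.5-fold higher number from compound 2 to compound 3 (0.18 log units; within the scatter), so the two stand within the scatter of each other; the other step is a 40-fold higher number from compound 1 to compound 3 (1.60 log units; beyond the scatter).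

Compound 4 `O=C(N[C@H]1CNC1=O)OCc1ccc(-c2ccccc2)cc1` differs from compound 3 in a single place: phenyl in place of cyclohexyloxy on an aromatic carbon. For the measured compounds named here, no measured pair reproduces this exact exchange. What the series does show is that replacing propyl by a six-membered ring on that aromatic carbon costs potency heavily, whether the ring is oxan-4-yl a 26-fold higher number from compound 1 to compound 2 (1.42 log units; beyond the scatter) or cyclohexyloxy a 40-fold higher number from compound 1 to compound 3 (1.60 log units; beyond the scatter), while exchanging one such ring for another a 1.5-fold higher number from compound 2 to compound 3 (0.18 log units; within the scatter) changes little. Phenyl is a third six-membered ring at the same position. One would therefore expect compound 4 to stay in the range of compounds 2 and 3, with a step of a 2.3-fold lower number from compound 3 to compound 4 (0.36 log units; beyond the scatter) that need not exceed the scatter. The estimate for compound 4 is 900 nM, between 250 nM and 3500 nM.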

Compound 4, half-maximal inhibitory concentration: 513 nM
Beside the measured number, compound 4's estimate is 1.8-fold (0.24 log units) above it; measured number inside the range.
By their numbers in this assay, from the lowest: compound 1; then compound 4; then compounds 2 and 3 (each within the scatter of the next).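

Until now the six-membered rings on this aromatic carbon could not be told apart, but phenyl separates from both of the others, with the number falling when it replaces cyclohexyloxy (a 4.0-fold lower number from compound 3 to compound 4 (0.61 log units; beyond the scatter)) and when it replaces oxan-4-yl (a 2.7-fold lower number from compound 2 to compound 4 (0.43 log units; beyond the scatter)). The position therefore does not treat every six-membered ring alike, although phenyl still falls short of propyl (a 9.9-fold higher number from compound 1 to compound 4 (0.99 log units; beyond the scatter)), so the ring recovers only part of what the first two rings lost. Nothing available here accounts for the difference between these groups.

Oxan-4-yl and cyclohexyloxy both carry an oxygen and neither ring is aromatic, so the compounds shown cannot say whether the lower number for compound 4 goes with the aromatic ring or with the absence of that oxygen; cyclohexyl, a carbon-only non-aromatic ring on the same carbon, would separate the two. As far as these compounds go, it also remains open whether a pyridyl ring would behave like phenyl, and whether a longer chain such as butyl would hold the number of propyl.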